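Amide aryl variation within the shared core series

The source may report more compounds than this note shows. Statements on the series, on what has been measured and on what is new or still open speak of the compounds shown alone.

The series keeps the core of compound 1 `O=C(Nc1ccccc1)c1cccc(/C=C2\CC(=O)N(c3ccccc3)C2=O)c1`, an anilide carrying no substituent on its terminal phenyl. In an ADME assay on HCT-116 cells (Homo sapiens) for cytotoxicity, read by MTT assay, with a stated time of 72 h (a lower number here means a stronger inhibitor, a higher number a weaker inhibitor), compound 1 gives > 100000 nM, which is a limit of the assay and not a number. Compound 2 `Cc1cccc(NC(=O)c2cccc(/C=C3\CC(=O)N(c4ccccc4)C3=O)c2)c1` carries methyl in place of hydrogen on an aromatic carbon. In this assay compound 2 gives > 100000 nM, again a limit and not a number. The step that the two limits leave unreadable from compound 1 to compound 2 cannot be sized because the limit of > 100000 nM in this assay, at which 2 of the 2 values shown sit, applies to both ends. Compound 2 therefore stands only at the limit, with no numerical position within the series.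

Compound 3 `O=C(Nc1ccc(OC(F)F)cc1)c1cccc(/C=C2\CC(=O)N(c3ccccc3)C2=O)c1` differs from compound 2 by 4-(difluoromethoxy)phenyl in place of 3-methylphenyl on an amide-type nitrogen. Going by the values given here, no measured step in this assay carries a readable size, so nothing constrains the direction or magnitude of the change beyond the scatter. The working expectation is that compound 3 remains at or near the limit. For compound 3 the estimated value is 150000 nM. For compound 3 the expected range runs from 50000 nM to 500000 nM. The step that the limit leaves unreadable from compound 2 to compound 3 is thus expected to be small, and most likely only a limit will again be reported.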

Compound 3, half-maximal inhibitory concentration: > 100000 nM
Compound 3 ended at the assay's limit; the forecaster's own chance of this, stated with the estimate: 80%; the middle value is on the limit's open side.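

No step between compound 1, compound 2 and compound 3 can be read in this assay, because all three sit at the same assay limit, which is not a number: the limit of > 100000 nM in this assay, at which 3 of the 3 values shown sit.

The compounds shown leave open whether any group on the amide-type nitrogen gives a numerical value in this assay, and how such groups would rank.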